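Trimming the Butylamino Chain: Working Notes

The source may hold more compounds than are shown below. What is called first, only, known or untested is meant among the compounds shown, and "the series" means these compounds.

compound 1 `CCCCNC1=CC(=O)C=C(C(C)(C)C)C1=O` gives 13000 nM in a functional assay on NCI-H460 cells (Homo sapiens) for cytotoxicity, read by MTT assay, with a stated time of 72 h; a higher number here means a weaker inhibitor, a lower number a stronger inhibitor
compound 2 `CC1=CCC[C@H]2[C@](C)(CC3=CC(=O)C=CC3=O)[C@@H](C)CC[C@]12C` gives 24000 nM in this assay

The two values lie within the usual scatter of each other, so compound 1 stands level with compound 2 and no ranking can be drawn from this pair. Going by the values given here, the two compounds also differ in more than one place, which leaves no measured step to scale from.

The next compound is compound 3 `CNC1=CC(=O)C=C(C(C)(C)C)C1=O`, which keeps the core of compound 1 and carries methylamino where compound 1 carries butylamino. This is hydrogen in place of propyl on a saturated chain carbon bound to an amine nitrogen.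

Among the compounds with values here, with no measured step to lean on, the expectation in this assay rests on compound 1 (at 13000 nM) and on the change itself. A small move toward a higher number is expected, and it may well stay within the scatter. The expected step is modest (a 1.5-fold higher number from compound 1 to compound 3 (0.19 log units; within the scatter)). Compound 3 is estimated at 20000 nM (expected range 8000 nM to 50000 nM).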

Compound 3, half-maximal inhibitory concentration: 23000 nM
For compound 3 the middle estimate is 1.2-fold (0.06 log units) below the measured one, within the range that was stated.
By their numbers in this assay, from the lowest: compounds 1, 3 and 2 (each within the scatter of the next).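

Going by these compounds alone, the first measured step comes from shortening butylamino to methylamino on the core of compound 1, and in this assay it reads a 1.8-fold higher number from compound 1 to compound 3 (0.25 log units; within the scatter). Compounds 1 and 3 therefore stand level: at this saturated chain carbon bound to an amine nitrogen, hydrogen can take the place of propyl, with its 3 carbon atoms, without a step beyond the scatter, so this pair gives no sign that the read-out depends on the length of the chain between methylamino and butylamino. No measurement of any property accompanies this step, so the data offer no account of it.

The compounds shown span only these two chain lengths on this core, so a plain amino group, a longer chain such as octylamino and a chain ending in a carboxylic acid all remain open. In this assay, from the compounds shown here alone, compound 1 gives 13000 nM, and also open is whether any such group would fall outside the scatter of that number, in either direction.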